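The source may hold more compounds than are shown below. What is called first, only, known or untested is meant among the compounds shown, and "the series" means these compounds.

Values so far in a physicochemical assay, with a stated time of 30 min (a lower number here means a stronger inhibitor, a higher number a weaker inhibitor), for the series:

compound 1 `COc1ccc(NC(=O)C2Cc3cc(OC)c(OC)cc3C2=O)cc1` gives 49.5 ug/mL here
compound 2 `COc1cc2c(cc1OC)C(=O)C(C(=O)Nc1ccc(F)cc1)C2` gives 55 ug/mL here
compound 3 `COc1cc2c(cc1OC)C(=O)C(C(=O)Nc1ccc(Br)cc1)C2` gives 72.1 ug/mL here

Compound 1 cannot be separated from the other two, as its steps to both lie within the scatter. On the aromatic ring of the anilide part, the measured steps are a 1.1-fold higher number from compound 1 to compound 2 (0.05 log units; within the scatter) for fluoro in place of methoxy on an aromatic carbon and a 1.5-fold higher number from compound 1 to compound 3 (0.16 log units; within the scatter) for bromo in place of methoxy on an aromatic carbon. The step between the two halogens, a 1.3-fold higher number from compound 2 to compound 3 (0.12 log units; within the scatter) for bromo in place of fluoro, is equally small.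

The next compound is compound 4 `CCc1cccc(NC(=O)C2Cc3cc(OC)c(OC)cc3C2=O)c1` and its change from compound 1 is 3-ethylphenyl in place of 4-methoxyphenyl on an amide-type nitrogen with the shared core untouched. For the measured compounds named here, no measured compound carries 3-ethylphenyl, so these steps bear on the change only indirectly and the data offer no direct precedent. They do show that three different groups on this ring leave the number within the scatter, and no step beyond the scatter is expected here.

The expected change is small: a 1.2-fold higher number from compound 1 to compound 4 (0.07 log units; within the scatter) is the estimated step. For compound 4 the estimated value is 58 ug/mL with an expected range from 32 ug/mL to 105 ug/mL in this series.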

Compound 4, half-maximal inhibitory concentration: 64.1 ug/mL
Estimate against measurement, compound 4: 1.1-fold (0.04 log units) below; low and high end bracket the measured number.
By their numbers in this assay, from the lowest: compounds 1, 2, 4 and 3 (each within the scatter of the next).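

In this assay, 3-ethylphenyl in place of 4-methoxyphenyl on an amide-type nitrogen gives a 1.3-fold higher number from compound 1 to compound 4 (0.11 log units; within the scatter) and so stays within the scatter, as do the comparisons with the halogen compounds, which give a 1.2-fold higher number from compound 2 to compound 4 (0.07 log units; within the scatter) and a 1.1-fold lower number from compound 3 to compound 4 (0.05 log units; within the scatter). For the compounds shown here, compound 4 is the first whose group on this nitrogen bears its ring substituent under the 3-name rather than the 4-name, and the first whose group is carbon only, with no hydrogen-bond acceptor, yet all four compounds remain inseparable. The data at hand offer no measurement that would explain this flat picture.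

No group on this nitrogen shown so far produces a step beyond the scatter, so it remains open whether a carboxylic acid, an amine or a longer chain such as hexyl on the same ring would do so. With ethyl shown only in 3-ethylphenyl and methoxy, fluoro and bromo shown only in the 4-named groups, the effect of ring position cannot be separated from that of the group itself.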